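A Chloro Group Added to Compound 2

A few compounds are considered here, and "the series" means these few. Any claim that something is new, unique, unknown or untested is made for them only; others in the source may bear on it.

In a functional assay on HCT-116 cells (Homo sapiens) for antiproliferative activity, read by sulforhodamine B assay, with a stated time of 48 h (a higher number here means a weaker inhibitor of growth, a lower number a stronger inhibitor of growth), compound 1 `COc1ccc(S(=O)(=O)c2nc3ccccc3cc2/C=C/C(=O)NO)cc1` gives > 10000 nM, which is a limit of the assay and not a number. Among the compounds with values here, compound 2 `O=C(/C=C/c1cccc(S(=O)(=O)c2ccc3ccccc3n2)c1)NO` gives 80 nM, the lower of the only two actual numbers so far. The other belongs to compound 3 `O=C(/C=C/c1ccc(S(=O)(=O)c2ccc3ccccc3n2)cc1)NO`, which gives 310 nM, and the gap between these two lies beyond the usual scatter of repeated measurements. Compound 2 is therefore the best starting point here, since a lower number means stronger inhibition of growth.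

Compound 4 `O=C(/C=C/c1cccc(S(=O)(=O)c2ccc3cc(Cl)ccc3n2)c1)NO` keeps all of compound 2 but makes one small change: chloro in place of hydrogen on an aromatic carbon. In words, chloro takes the place of hydrogen on an aromatic carbon, in a six-membered aromatic ring of carbon only that is part of a fused system of two rings. Within the data shown here, no measured pair shows what this exchange does, so the direction of any shift remains open. The expectation rests on compound 2 at 80 nM and on how little of the structure changes. The estimate is a small step, a 1.1-fold lower number from compound 2 to compound 4 (0.06 log units; within the scatter), not beyond the scatter. Compound 4 is expected at 70 nM, with an estimated range from 25 nM to 220 nM.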

Compound 4, concentration for 50% growth inhibition: 920 nM
Compound 4: middle estimate off by 13-fold (1.12 log units), on the low side, and the stated range ends below it.
By their numbers in this assay, from the lowest: compound 2; then compound 3; then compound 4. At a limit, above all of these: compound 1.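

In this assay, the exchange of hydrogen for chloro is far from a quiet one, giving a 12-fold higher number from compound 2 to compound 4 (1.06 log units; beyond the scatter), so compound 4 is a clearly weaker inhibitor of growth than its parent. Within the data shown here, the earlier compounds could not show this, since no two of them differ in one place only; this pair is the first direct reading of a single change, and it shows that growth inhibition responds strongly to what sits on this aromatic carbon, meta to a fused ring and para to a fused ring, with hydrogen the better of the two groups compared there. Nothing measured in this set gives a reason for the loss, so the size of the step stands as an observation without an explanation.

As far as these compounds go, what stays open is whether any group on this carbon costs as much, or whether the loss belongs to chloro alone, and a fluoro group or an amine in the same place would be a direct test of that. From the compounds shown here alone, it is equally open whether chloro on another carbon of this ring would give a similar step.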